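This account rests on a few compounds, and the source may have more. Where it says the series, first, only, none or still open, it means among the compounds named here.

Compound 3, `Cc1cc(C#N)cc(C)c1Oc1nc(Nc2ccc(C#N)cc2)ncc1Cl`, gives 1.54 in a physicochemical assay for lipophilicity; a lower number here means a more polar compound, a higher number a more lipophilic compound. Among the three measured compounds it stands second highest: compound 2, `Cc1cc(C#N)cc(C)c1Nc1nc(Nc2ccc(C#N)cc2)ncc1C#N`, gives 1.31, a value within the scatter of compound 3, while compound 1, `C=Cc1cnc(Nc2ccc(C#N)cc2)nc1Nc1c(C)cc(C#N)cc1C`, gives 2.36, well above it. Compound 4, `CC(=O)Nc1cnc(Nc2ccc(C#N)cc2)nc1Oc1c(C)cc(C#N)cc1C`, differs from compound 3 by acetamido in place of chloro on an aromatic carbon. Among the measured compounds shown here, only one measured step is available, a number 1.05 log units lower from compound 1 to compound 2 (beyond the scatter), and it concerns a different exchange on the same aromatic carbon of the shared core, so it bears on the present step only loosely; it shows that a single exchange at this place can move the value in this assay by a large amount, well beyond the scatter. The entering group brings one hydrogen-bond donor and one acceptor where the leaving chloro brought none, so a step downward beyond the scatter is expected, with a number 0.84 log units lower from compound 3 to compound 4 (beyond the scatter) as the estimated size. Compound 4 is therefore expected to give about 0.7 in this assay, within a range from 0.1 to 1.3.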

Compound 4, partition coefficient: -0.12
Estimate against measurement, compound 4: 0.82 log units above; measured number outside the range, below it.
By their numbers in this assay, from the lowest: compound 4; then compounds 2 and 3 (each within the scatter of the next); then compound 1.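

In this assay, acetamido in place of chloro on this aromatic carbon gives a number 1.66 log units lower from compound 3 to compound 4 (beyond the scatter), which shows that this position responds strongly to a change of group in a second matched pair, not only in the pair of compound 1 and compound 2. Both steps measured at this carbon now run downward, and both are large, although the entering and leaving groups differ between the two pairs. No measured evidence accounts for the size of this step.

The compounds shown leave open whether the whole acetamido group is needed for a step of this size, or whether an amine, a methoxy group or a longer acyl chain on this carbon would give a similar one. From the compounds shown here alone, it also remains open whether the same exchange would give a similar step on the core of compound 1.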